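Cyclopropyl for methyl: an untested step from compound 3

The source may report more compounds than this note shows. Statements on the series, on what has been measured and on what is new or still open speak of the compounds shown alone.

Among the compounds with values here, compound 3 `Cc1ncncc1-c1nc2cc(F)c(F)cc2n1C1CC1` gives 4160 nM in an ADME assay on cells for inhibition of cytochrome P450 11B1, mitochondrial (Homo sapiens), read by HPLC, with a stated time of 60 min (on this read-out higher numbers stand for weaker inhibition and lower numbers for stronger inhibition), the lowest of the two numbers so far. Compound 1 `Fc1ccc2nc(-n3ccnn3)n(C3CC3)c2c1` gives 9070 nM in this assay and sits above compound 3 by a gap beyond the usual scatter. Compound 2 `Fc1ccc2nc(-c3cnco3)n(C3CC3)c2c1` gives > 10000 nM in this assay, which is a limit of the assay and not a number (the limit of > 10000 nM in this assay, at which 1 of the 3 values shown sits). Within the data shown here, the one measured step within the set, an at least 1.1-fold higher number from compound 1 to compound 2 (0.04 log units; that floor lies within the scatter), exchanges one five-membered ring for another on the shared core and stays within the scatter.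

Compound 4 `Fc1cc2nc(-c3cncnc3C3CC3)n(C3CC3)c2cc1F` differs from compound 3 by cyclopropyl in place of methyl on an aromatic carbon. Among the measured compounds shown here, no measured step touches this place or this pair of groups; the step in hand, an at least 1.1-fold higher number from compound 1 to compound 2 (0.04 log units; that floor lies within the scatter), concerns a different ring at a different position and was itself within the scatter. With nothing pointing to a shift, the expected step of a 1.0-fold lower number from compound 3 to compound 4 (0.02 log units; within the scatter) is none beyond the scatter. Compound 4 is therefore estimated at 4000 nM in this assay, with a range from 1500 nM to 11000 nM.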

Compound 4, half-maximal inhibitory concentration: > 10000 nM
Compound 4: only a limit was reported; the forecaster's own chance of this, stated with the estimate: 12%; middle value at least 2.5-fold (0.39 log units) from the limit.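

In this assay, cyclopropyl in place of methyl on an aromatic carbon of the six-membered aromatic ring with 2 nitrogen gives an at least 2.4-fold higher number from compound 3 to compound 4 (0.38 log units; beyond the scatter), which shows that the group at this place matters for this read-out. Within the data shown here, this is the first step in the set beyond the scatter, and it runs towards weaker inhibition, whereas the only earlier step, an exchange of one five-membered ring for another, stayed within the scatter. Compound 4 gives > 10000 nM, which is a limit of the assay and not a number, so the step is only a floor and its full size cannot be read: the limit of > 10000 nM in this assay, at which 2 of the 4 values shown sit.

Only methyl and cyclopropyl are shown at this place, leaving open how an ethyl chain, a methoxy group or an amine there would read. Also open, from the compounds shown here alone, is whether a group at this place could bring a lower number than compound 3 gives.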